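Swapping a Pyridine for a Pyrimidine in a Cytotoxicity Screen

The compounds below may be only part of what the source reports. "The series", "measured", "known", "first", "only" and "open" are said of these compounds alone.

Compound 2 `O=c1nc(-c2ccccc2)c2ccc(-c3ccncc3)cc2[nH]1` was tested in an ADME assay on THP-1 cells (Homo sapiens) for cytotoxicity, read by MTT assay, with a stated time of 72 h; a higher number here means that more compound is needed for the effect, a lower number that less compound is needed. In this assay compound 2 gives > 50000 nM, which is a limit of the assay rather than a measured number. Compound 1 `O=c1nc(-c2ccccc2)c2cc(-c3cncnc3)ccc2[nH]1`, which carries the same ring groups on the shared core, was tested as well. In this assay compound 1 gives > 50000 nM, again a limit of the assay. Both values shown thus sit at the same limit (the limit of > 50000 nM in this assay, at which 2 of the 2 values shown sit). Compound 3 `O=c1nc(-c2ccccc2)c2ccc(-c3cncnc3)cc2[nH]1` is the next compound, and it differs from compound 2 by one change: pyrimidin-5-yl in place of pyridin-4-yl on an aromatic carbon. Among the compounds with values here, no measured step between any two compounds exists in this set. Given that every value so far is a limit, the step from compound 2 to compound 3 in this assay is expected to be none beyond the scatter, a step that the limit leaves unreadable from compound 2 to compound 3. For compound 3 the expected value in this assay is 60000 nM, within 30000 nM to 150000 nM, most likely reported once more only as a limit.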

Compound 3, half-maximal effective concentration: > 50000 nM
Compound 3: only a limit was reported; the forecaster's own chance of this, stated with the estimate: 85%; the middle value is on the limit's open side.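

Compound 2 and compound 3 both stop at a limit of the assay, so no step between them can be read in this assay: the limit of > 50000 nM in this assay, at which 3 of the 3 values shown sit.

The compounds shown leave open whether pyrimidin-5-yl in place of pyridin-4-yl changes the concentration needed for cytotoxicity at all.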